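Changing the aryl group on a shared core

The compounds below may be only part of what the source reports. "The series", "measured", "known", "first", "only" and "open" are said of these compounds alone.

Within the data shown here, compound 2 `Cn1c(=O)c(=O)n(C2CCCC2)c2nc(N/N=C/c3cccc([N+](=O)[O-])c3)ncc21` has been tested in a functional assay on PC-3 cells (Homo sapiens) for antiproliferative activity, read by MTT assay (a lower number here means a stronger inhibitor, a higher number a weaker inhibitor), where compound 2 gives 20300 nM, a number that sits within the scatter of the only other number known. That other number belongs to compound 1 `Cn1c(=O)c(=O)n(C2CCCC2)c2nc(N/N=C/c3ccc(F)cc3Cl)ncc21`, which gives 15200 nM in this assay; the step of a 1.3-fold higher number from compound 1 to compound 2 (0.13 log units; within the scatter) exchanged one aryl group for another. Compound 3 `Cn1c(=O)c(=O)n(C2CCCC2)c2nc(N/N=C/c3ccccc3F)ncc21` is not yet measured and differs from compound 2 by 2-fluorophenyl in place of 3-nitrophenyl on a carbon with a double bond to nitrogen. Among the measured compounds shown here, the one comparable step, a 1.3-fold higher number from compound 1 to compound 2 (0.13 log units; within the scatter), also swapped an aryl group and stayed within the scatter, so no step beyond the scatter is expected in this assay. Compound 3 is therefore estimated at 16000 nM, between 6000 nM and 45000 nM. That estimate means an expected 1.3-fold lower number from compound 2 to compound 3 (0.10 log units; within the scatter).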

Compound 3, half-maximal inhibitory concentration: 27600 nM
Estimate against measurement, compound 3: 1.7-fold (0.24 log units) below, and the stated range covers the measured number.
By their numbers in this assay, from the lowest: compounds 1, 2 and 3 (each within the scatter of the next).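

Swapping 3-nitrophenyl for 2-fluorophenyl on a carbon with a double bond to nitrogen gives, in this assay, a step that stays within the scatter (a 1.4-fold higher number from compound 2 to compound 3 (0.13 log units; within the scatter)). Swapping 2-chloro-4-fluorophenyl for 2-fluorophenyl does the same (a 1.8-fold higher number from compound 1 to compound 3 (0.26 log units; within the scatter)). Three differently substituted phenyl groups at this position therefore cannot be told apart in this assay, and no outside evidence bears on this result. All three groups are substituted phenyl rings. As far as these compounds go, whether an amine, a carboxylic acid or a saturated ring such as cyclohexyl at this position would produce a step beyond the scatter remains open.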